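A few compounds are considered here, and "the series" means these few. Any claim that something is new, unique, unknown or untested is made for them only; others in the source may bear on it.

Working notes on the series. Compound 1 `COc1cccc(NC(=O)c2cnn(-c3ccc(F)cc3)c2C)c1` and compound 2 `Cc1cccc(NC(=O)c2cnn(-c3ccc(F)cc3)c2C)c1` share one core and differ only on one aromatic carbon. In a functional assay with Homo sapiens as the target (on this read-out higher numbers stand for weaker inhibition and lower numbers for stronger inhibition), compound 1 gives 3700 nM and compound 2 gives 5700 nM; the step of a 1.5-fold higher number from compound 1 to compound 2 (0.19 log units; within the scatter) lies within the scatter, so the two numbers cannot be ordered. Compound 2 thus stands level with compound 1 on the two numbers in hand.

Compound 3 `Cc1c(C(=O)Nc2cccc(C(F)(F)F)c2)cnn1-c1ccc(F)cc1` carries the change trifluoromethyl in place of methyl on an aromatic carbon on an aromatic carbon of a six-membered aromatic ring of carbon only. Within the data shown here, no measured pair shows this change; the only pair in hand, from compound 1 to compound 2, shows that a small group swapped at this position moved the read-out within the scatter. On that basis the step of a 1.1-fold lower number from compound 2 to compound 3 (0.06 log units; within the scatter) is expected to be small. Compound 3 is estimated at 5000 nM in this assay, within the range 1800 nM to 14000 nM.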

Compound 3, half-maximal inhibitory concentration: 1700 nM
For compound 3 the middle estimate is 2.9-fold (0.47 log units) above the measured one; measured number outside the range, below it.
By their numbers in this assay, from the lowest: compound 3; then compounds 1 and 2 (each within the scatter of the next).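

In this assay the group at this position, on a six-membered aromatic ring of carbon only and meta to a large group, does move the read-out: trifluoromethyl in place of methyl gives a 3.4-fold lower number from compound 2 to compound 3 (0.53 log units; beyond the scatter) and trifluoromethyl in place of methoxy gives a 2.2-fold lower number from compound 1 to compound 3 (0.34 log units; beyond the scatter) as well. Compounds 1 and 2 could not be ordered, whereas compound 3 stands apart from both, with modest steps beyond the scatter. Nothing in hand accounts for this difference.

From the compounds shown here alone, whether a nitrile, an amine or a carboxylic acid at this position would give a number near that of compound 3 stays open. Also open, going by these compounds, is whether trifluoromethyl would give a similar step if the fluorine on the other aromatic ring were replaced by a different group.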